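Taking the methoxy off compound 2

A few compounds are considered here, and "the series" means these few. Any claim that something is new, unique, unknown or untested is made for them only; others in the source may bear on it.

Compound 1 (`CN1CCN(c2nc(-c3ccc(Cl)cc3)cc3c(N(C)C)cccc23)CC1`): 7560 nM
Compound 2 (`COc1ccc(-c2cc3c(N(C)C)cccc3c(N3CCN(C)CC3)n2)cc1`): 13200 nM

In a functional assay on SK-OV-3 cells (Homo sapiens) for cytotoxicity (a lower number here means a stronger inhibitor, a higher number a weaker inhibitor), compound 2 stands at 13200 nM within the scatter of compound 1. Compound 3 (`CN1CCN(c2nc(-c3ccccc3)cc3c(N(C)C)cccc23)CC1`) carries hydrogen in place of methoxy on an aromatic carbon. Among the compounds with values here, the only measured step at this place is a 1.7-fold higher number from compound 1 to compound 2 (0.24 log units; within the scatter) with methoxy in place of chloro, and it stayed within the scatter. No step beyond the scatter is therefore expected in this assay for this change. The estimated step is a 1.3-fold lower number from compound 2 to compound 3 (0.12 log units; within the scatter) and lies within the scatter. Compound 3 is expected at 10000 nM with an estimated range from 5000 nM to 20000 nM in this measurement.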

Compound 3, half-maximal inhibitory concentration: 11200 nM
Compound 3: middle estimate off by 1.1-fold (0.05 log units), on the low side; low and high end bracket the measured number.
By their numbers in this assay, from the lowest: compounds 1, 3 and 2 (each within the scatter of the next).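

In this assay, within the data shown here, the place on the aromatic carbon, para to a large group, now holds hydrogen as well as methoxy and chloro: hydrogen in place of methoxy gives a 1.2-fold lower number from compound 2 to compound 3 (0.07 log units; within the scatter) while hydrogen in place of chloro gives a 1.5-fold higher number from compound 1 to compound 3 (0.17 log units; within the scatter) so even with no substituent at all, no step here leaves the scatter. No supporting evidence bears on this result. Going by these compounds, whether an amine, a carboxylic acid or a longer chain at this place would give a step beyond the scatter stays open, as does the effect of changes elsewhere on the shared core.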